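Swapping the group on the ring nitrogen of compound 2

The source may report more compounds than this note shows. Statements on the series, on what has been measured and on what is new or still open speak of the compounds shown alone.

Two compounds share one core and differ only in the group carried on an aromatic nitrogen. Compound 1 `CCOC(=O)c1ccc(-c2nn(Cc3cccc(F)c3)c3ccccc23)cc1` gives 270 nM in a functional assay on cells (Platelet, Homo sapiens) for inhibition; a lower number here means a stronger inhibitor, a higher number a weaker inhibitor. Compound 2 `CCOC(=O)c1ccc(-c2nn(Cc3ccncc3)c3ccccc23)cc1` gives 5630 nM in this assay, the highest of the two numbers, and the step of a 21-fold higher number from compound 1 to compound 2 (1.32 log units; beyond the scatter) shows that a change at this position can shift the number a great deal. Compound 3 `CCOC(=O)c1ccc(-c2nn(-c3ccco3)c3ccccc23)cc1` carries a different group at the same place: furan-2-yl in place of (pyridin-4-yl)methyl on an aromatic nitrogen. For the measured compounds named here, the single measured step bears on it only in showing that this position matters; no measured pair tells how a five-membered ring bound directly to the nitrogen compares with a ring joined through a saturated chain carbon. A moderate move back toward compound 1 is therefore expected, with wide uncertainty, as a 3.8-fold lower number from compound 2 to compound 3 (0.57 log units; beyond the scatter). For compound 3 the estimate is 1500 nM, within 300 nM to 8000 nM.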

Compound 3, half-maximal inhibitory concentration: 340 nM
The estimate for compound 3 lay 4.4-fold (0.64 log units) above the measured number; low and high end bracket the measured number.
By their numbers in this assay, from the lowest: compounds 1 and 3 (each within the scatter of the next); then compound 2.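

In this assay, furan-2-yl on the aromatic nitrogen recovers what was lost with (pyridin-4-yl)methyl, giving a 17-fold lower number from compound 2 to compound 3 (1.22 log units; beyond the scatter) as the size of that change. Set against 3-fluorobenzyl, it gives a 1.3-fold higher number from compound 1 to compound 3 (0.10 log units; within the scatter) and so leaves compound 1 and compound 3 level, which shows that a ring bound directly to the nitrogen can match one joined through a saturated chain carbon. Nothing available here explains why compound 2 stands apart from the other two.

Still open, from the compounds shown here alone, is whether the level result of compound 3 belongs to the furan ring itself or to its direct attachment; a phenyl ring bound directly to the nitrogen and a (furan-2-yl)methyl group would separate the two. How a plain benzyl group or an amine on a longer chain would fare at this place is also unknown.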